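Topoisomerase Series: Dimethylamino Replacing Trifluoromethoxy

This account rests on a few compounds, and the source may have more. Where it says the series, first, only, none or still open, it means among the compounds named here.

Three compounds of one shared core have numbers in an assay on isolated protein for inhibition of DNA topoisomerase 1 (Homo sapiens), with a stated time of 30 min, tested at 100 uM; a higher number here means a stronger effect of the compound at the concentration tested, a lower number a weaker effect. Compound 1 `Cc1ccc2nc(-c3ccccc3N(C)C)[nH]c(=O)c2c1` gives 82.9%. Compound 2 `CCN(CC)c1ccc2nc(-c3ccccc3OC(F)(F)F)[nH]c(=O)c2c1` gives 81.2%, and compound 3 `Cc1ccc2c(=O)[nH]c(-c3ccccc3F)nc2c1` gives 81.2%. Compound 2 is level with compound 3 at the digits shown, these two being together the lowest of the three numbers, and its gap to compound 1 is within the scatter, so the three values cannot be ordered.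

The step under consideration leads from compound 2 to compound 4 `CCN(CC)c1ccc2nc(-c3ccccc3N(C)C)[nH]c(=O)c2c1`, not yet measured in this assay. The change: dimethylamino in place of trifluoromethoxy on an aromatic carbon. Compound 4 thus carries the dimethylamino of compound 1 on the six-membered aromatic ring of carbon only, and keeps the diethylamino of compound 2 on the core. Among the compounds with values here, no step between measured compounds differing in one place is available, so there is no direct precedent. Since compound 1 with the dimethylamino gives 82.9% and compound 2 gives 81.2%, both in the same narrow band, the expected step is a number 0.8 percentage points higher from compound 2 to compound 4 (within the scatter), none beyond the scatter. Compound 4 is estimated at 82%, with a range from 70% to 92%.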

Compound 4, a percentage reported as inhibition, at one concentration (the size of the read-out at that concentration, not a potency): 82.1%
Beside the measured number, compound 4's estimate is 0.1 percentage points below it; low and high end bracket the measured number.
By their numbers in this assay, from the lowest: compounds 2, 3, 4 and 1 (each within the scatter of the next).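

In this assay, the series now has direct single-place comparisons at both sites of compound 4. Dimethylamino in place of trifluoromethoxy, on an aromatic carbon ortho to a large group, gives a number 0.9 percentage points higher from compound 2 to compound 4 (within the scatter), so this position tolerates either group with no difference that can be read at this concentration. Diethylamino in place of methyl on an aromatic carbon of the shared core gives a number 0.8 percentage points lower from compound 1 to compound 4 (within the scatter), so the two groups also cannot be told apart on the core, and nothing measured here offers an explanation for either result.

Each number is the size of the read-out at one concentration, so whether any of these compounds would show a stronger or weaker effect at another concentration remains open. Also open, going by these compounds, is whether a carboxylic acid or a longer chain at the position ortho to a large group would move the number beyond the scatter.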